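Trimethoxyphenyl Chalcone-Pyrazoles: Estimating a Third Methoxy Group

The source may hold more compounds than are shown below. What is called first, only, known or untested is meant among the compounds shown, and "the series" means these compounds.

Measured in a functional assay on SW-620 cells (Homo sapiens) for inhibition, read by sulforhodamine B assay, with a stated time of 48 h; on this read-out higher numbers stand for weaker inhibition of growth and lower numbers for stronger inhibition of growth:
compound 1 `COc1cc(-c2cc(/C=C/C(=O)c3ccc(N)cc3)[nH]n2)cc(OC)c1OC` gives 2050 nM
compound 2 `COc1ccc(C(=O)/C=C/c2cc(-c3cc(OC)c(OC)c(OC)c3)n[nH]2)cc1OC` gives 1370 nM
compound 3 `COc1cc(-c2cc(/C=C/C(=O)c3ccc(F)c(F)c3)[nH]n2)cc(OC)c1OC` gives 3420 nM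

Compound 2 shows the lowest number of the three; compound 1 sits close to it (a 1.5-fold lower number from compound 1 to compound 2 (0.18 log units; within the scatter)), while compound 3 lies further off (a 2.5-fold higher number from compound 2 to compound 3 (0.40 log units; beyond the scatter)). Compound 4 `COc1cc(C(=O)/C=C/c2cc(-c3cc(OC)c(OC)c(OC)c3)n[nH]2)cc(OC)c1OC` differs from compound 2 by methoxy in place of hydrogen on an aromatic carbon. Going by the values given here, no measured pair shows this exact change; the steps that bear on it only swap the whole aryl group on the carbonyl carbon, and together they span a modest range, from a 1.7-fold higher number from compound 1 to compound 3 (0.22 log units; within the scatter) to a 2.5-fold higher number from compound 2 to compound 3 (0.40 log units; beyond the scatter). Given that narrow spread, no step beyond the scatter is expected in this assay for compound 4, with the estimated change being a 1.2-fold lower number from compound 2 to compound 4 (0.10 log units; within the scatter). Compound 4 is therefore estimated at 1100 nM, within a range from 400 nM to 3500 nM.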

Compound 4, concentration for 50% growth inhibition: 1590 nM
Beside the measured number, compound 4's estimate is 1.4-fold (0.16 log units) below it, within the range that was stated.
By their numbers in this assay, from the lowest: compounds 2, 4, 1 and 3 (each within the scatter of the next, the first and the last beyond it).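

In this assay, methoxy in place of hydrogen on an aromatic carbon, ortho to a methoxy group, gives a 1.2-fold higher number from compound 2 to compound 4 (0.06 log units; within the scatter). The earlier steps shown here swapped the whole aryl group on the carbonyl carbon, whereas this one reads a single added group on that aryl ring and finds no change beyond the scatter. No measurement at hand gives a reason for this result.

Going by these compounds, whether an amine or a longer chain such as ethoxy at this place would also stay within the scatter of compound 2 remains open.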